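The source may report more compounds than this note shows. Statements on the series, on what has been measured and on what is new or still open speak of the compounds shown alone.

Measured so far:
- compound 1 `Cc1nc(S(C)(=O)=O)ccc1Oc1ncnc(OC2CCN(C(=O)OC(C)(C)C#N)CC2)c1F`: 97%
- compound 2 `Cc1nc(S(C)(=O)=O)ccc1Oc1ncnc(OC2CCN(C(=O)OC(C)(C)CF)CC2)c1F`: 95%
- compound 3 `Cc1nc(S(C)(=O)=O)ccc1Oc1ncnc(OC2CCN(C(=S)OC3(C)CC3)CC2)c1F`: 49%

In a functional assay on isolated protein for inhibition of Glucose-dependent insulinotropic receptor (Rattus norvegicus), read by HTRF and cAMP accumulation (on this read-out higher numbers stand for larger maximal responses and lower numbers for smaller maximal responses), compound 1 gives 97% and compound 2 gives 95%; compound 3 gives 49%. Compound 2 stands second highest of the three numbers, with compound 1 the nearest to it, the step of a number 2 percentage points lower from compound 1 to compound 2 (within the scatter), and compound 3 the furthest, the step of a number 46 percentage points lower from compound 2 to compound 3 (beyond the scatter).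

Compound 4 `Cc1nc(S(C)(=O)=O)ccc1Oc1ncnc(OC2CCN(C(=O)C3CCCC3)CC2)c1F` has not yet been measured. It differs from compound 2 on the carbonyl carbon: a group of 5 heavy atoms (5 carbon; one five-membered non-aromatic ring of carbon only) in place of a group of 6 heavy atoms (4 carbon, 1 oxygen, 1 fluorine; no ring), on a carbonyl carbon.

Among the measured compounds shown here, two measured steps bear on this. The step of a number 2 percentage points lower from compound 1 to compound 2 (within the scatter) shows that an exchange within the chain on the carbamate side leaves the maximal response unchanged. The steps of a number 48 percentage points lower from compound 1 to compound 3 (beyond the scatter) and a number 46 percentage points lower from compound 2 to compound 3 (beyond the scatter) show that a larger rebuild of the group on the ring nitrogen, bringing in a three-membered ring, cuts the maximal response roughly in half. The change to compound 4 is also a rebuild at the carbonyl carbon, bringing in a ring, and is therefore expected to lower the response in this assay, though the data do not show whether to the extent seen for compound 3.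

Compound 4 is expected to give 70% in this assay, within 40% to 100%, a step of a number 25 percentage points lower from compound 2 to compound 4 (beyond the scatter) estimated from compound 2.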

Compound 4, largest response reached (reported as efficacy), in percent of the reference or control that the assay uses: 83%
The estimate for compound 4 lay 13 percentage points below the measured number, and the stated range covers the measured number.
By their numbers in this assay, from the lowest: compound 3; then compound 4; then compounds 2 and 1 (each within the scatter of the next).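

In this assay, cyclopentyl on the carbonyl carbon keeps most of the maximal response, with only modest losses in a number 12 percentage points lower from compound 2 to compound 4 (beyond the scatter) and a number 14 percentage points lower from compound 1 to compound 4 (beyond the scatter), so this position accepts a carbon-only ring with no hydrogen-bond acceptor in the entering group. The large gain in a number 34 percentage points higher from compound 3 to compound 4 (beyond the scatter) shows that a ring in the group on the ring nitrogen does not in itself bring the deep loss seen for compound 3, although ring size, the oxygen link and the sulfur all change together in that step, so it cannot be assigned to any one of them. No measurement at hand explains the size of any of these steps.

Open, as far as these compounds go, is whether the response on the carbonyl carbon depends on ring size, as a cyclobutyl or cyclohexyl group would show, or changes when the cyclopentyl ring carries an amine or a carboxylic acid. Also open, from the compounds shown here alone, is whether sulfur alone, exchanged for the carbonyl oxygen in an otherwise unchanged carbamate, accounts for the low number of compound 3.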